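Side-chain change from compound 3 to compound 4

This account rests on a few compounds, and the source may have more. Where it says the series, first, only, none or still open, it means among the compounds named here.

In a functional assay on HepG2 cells (Homo sapiens) for inhibition, read by MTT assay, with a stated time of 48 h (a lower number here means a stronger inhibitor, a higher number a weaker inhibitor), compound 1 (`C[Se]c1ccc(N(C)c2nc(C3CC3)nc3ccccc23)cc1`) gives 32 nM, compound 3 (`COc1ccc(N(C)c2nc(C)nc3ccccc23)cc1C(=O)OCCC[Se]C#N`) gives 340 nM and compound 2 (`COc1ccc(N(C)c2nc(C)nc3ccccc23)cc1OCCCCCC[Se]C#N`) gives 4890 nM. Compound 3 therefore holds the middle place among the three numbers, above compound 1 and below compound 2.

Compound 4 (`COc1ccc(N(C)c2nc(C)nc3ccccc23)cc1OCC[Se]C#N`) has not been measured. Its difference from compound 3 is a group of 6 heavy atoms (3 carbon, 1 nitrogen, 1 oxygen, 1 selenium; no ring) in place of a group of 9 heavy atoms (5 carbon, 1 nitrogen, 2 oxygen, 1 selenium; no ring), on an aromatic carbon. The change lies on an aromatic carbon of a six-membered aromatic ring of carbon only, ortho to a methoxy group and meta to a large group.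

Within the data shown here, one measured step bears on this carbon: a 14-fold lower number from compound 2 to compound 3 (1.16 log units; beyond the scatter), a large step. It shows that replacing the group here can move the number well beyond the scatter. Compound 1 differs in more than one place and gives no direct guide. Compound 3 has the lower number of the two compounds measured with a long group on this carbon, so moving away from its group is expected to raise the number, probably by less than a 14-fold lower number from compound 2 to compound 3 (1.16 log units; beyond the scatter). The expected change in this assay is a 2.6-fold higher number from compound 3 to compound 4 (0.42 log units; beyond the scatter), and one measured step leaves this direction uncertain. Compound 4 is estimated at 900 nM, with an expected range of 250 nM to 3500 nM.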

Compound 4, half-maximal inhibitory concentration: 14 nM
For compound 4 the middle estimate is 64-fold (1.81 log units) above the measured one; the measured number lies below the stated range.
By their numbers in this assay, from the lowest: compound 4; then compound 1; then compound 3; then compound 2.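

In this assay, a 24-fold lower number from compound 3 to compound 4 (1.39 log units; beyond the scatter) shows that the group on this aromatic carbon can lower the number as well as raise it, and that the ester-linked group of compound 3 is not the best of those measured here. With the aromatic oxygen kept and only the saturated chain shortened, a 350-fold lower number from compound 2 to compound 4 (2.54 log units; beyond the scatter) shows that chain length alone moves the number strongly. Across compound 2, compound 3 and compound 4 the number falls as the group on this carbon gets smaller, with none of the three going against this, though no measurement shown accounts for the trend.

Three groups on one carbon cannot show whether the number keeps falling with a still shorter chain or rises again, or how chains of intermediate length behave on the ether link. Also open, from the compounds shown here alone, is how much of the result depends on the nitrile on selenium, which a methyl group on selenium at the end of the same chain would test, and whether an amine or amide link in place of the ring oxygen would preserve it.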